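The source may report more compounds than this note shows. Statements on the series, on what has been measured and on what is new or still open speak of the compounds shown alone.

Notes on the series.

Compound 1 `COc1ccccc1N1CCN(CCCNc2ncccc2C(=O)N(C)C)CC1` is the reference; in a functional assay for antagonist activity at Alpha-1A adrenergic receptor (Oryctolagus cuniculus) (a higher number here means weaker binding, a lower number tighter binding), compound 1 gives 1.59 nM. Compound 2 `Cc1ccccc1N1CCN(CCCNc2ncccc2C(=O)N(C)C)CC1` differs from compound 1 by methyl in place of methoxy on an aromatic carbon; in this assay compound 2 gives 2 nM, a step of a 1.3-fold higher number from compound 1 to compound 2 (0.10 log units; within the scatter). Compound 3 `COc1ccc(N2CCN(CCCNc3ncccc3C(=O)N(C)C)CC2)c(OC)c1` carries a second methoxy group, and in this assay compound 3 gives 31.6 nM; the step is a 20-fold higher number from compound 1 to compound 3 (1.30 log units; beyond the scatter), and against compound 2 it is a 16-fold higher number from compound 2 to compound 3 (1.20 log units; beyond the scatter). Compound 4 `COc1cc(C)ccc1N1CCN(CCCNc2ncccc2C(=O)N(C)C)CC1` is not yet measured.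

The change from compound 3 to compound 4 is methyl in place of methoxy on an aromatic carbon. Within the data shown here, it is the same kind of change as the one made from compound 1 to compound 2, methyl in place of methoxy on an aromatic carbon, but not at the same place: in the first pair the aromatic carbon is ortho to a large group, in the second it is meta to a methoxy group and para to a large group. The two cores differ by methoxy in place of hydrogen on an aromatic carbon.

Among the measured compounds shown here, the one measured precedent for this kind of change, a 1.3-fold higher number from compound 1 to compound 2 (0.10 log units; within the scatter), lies within the scatter. The place itself is sensitive, since compound 3 lost a 20-fold higher number from compound 1 to compound 3 (1.30 log units; beyond the scatter) against compound 1 on gaining the methoxy there; whether a methyl at that place costs as much is not shown. The expected step is therefore small, a 1.6-fold lower number from compound 3 to compound 4 (0.20 log units; within the scatter), leaning toward a slight recovery, with wide uncertainty. For compound 4 in this assay the estimate is 20 nM, expected between 5 nM and 60 nM.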

Compound 4, dissociation constant: 0.794 nM
Compound 4: the middle estimate sits 25-fold (1.40 log units) above what was measured, and the stated range ends above it.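

Methyl in place of methoxy does not behave as a fixed step across the two cores in this assay: the same change on two cores in this assay, a 1.3-fold higher number (0.10 log units; within the scatter) from compound 1 to compound 2 and a 40-fold lower number (1.60 log units; beyond the scatter) from compound 3 to compound 4, 50-fold (1.70 log units) apart, beyond the scatter of two such steps

At the carbon para to a large group, the replacement gives a 40-fold lower number from compound 3 to compound 4 (1.60 log units; beyond the scatter), so the high number of compound 3 does not extend to compound 4; the methyl leaves compound 4 with a 2.0-fold lower number from compound 1 to compound 4 (0.30 log units; within the scatter), and against the other methyl-bearing compound the result is a 2.5-fold lower number from compound 2 to compound 4 (0.40 log units; beyond the scatter). This shows that a step measured at one place on the aryl ring of the shared core gave no usable guide to the same replacement at another place, but it rests on two pairs in which place and core change together, so it cannot say which of the two accounts for the gap, and the large step hangs on compound 3 alone.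

The compounds shown leave open whether the high number of compound 3 is particular to methoxy at that carbon, or whether a fluorine, a chlorine, a hydroxyl or an ethyl group there would behave like methoxy or like methyl. Also open, on these data alone, is how a methyl at that same carbon reads on the core of compound 2, where the group on the other ring carbon is methyl rather than methoxy.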